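The compounds below may be only part of what the source reports. "The series", "measured", "known", "first", "only" and "open" are said of these compounds alone.

Measured compounds:
- compound 1, `O=C(/C=C/c1ccccc1)c1ccc2[nH]c(=O)oc2c1`, in a functional assay on BV-173 cells (Homo sapiens) for cytotoxicity, read by MTT assay, with a stated time of 72 h (a higher number here means a weaker inhibitor, a lower number a stronger inhibitor), compound 1 gives 18400 nM
- compound 2, `COc1ccc(/C=C/C(=O)c2ccc3[nH]c(=O)oc3c2)cc1`, in this assay compound 2 gives 9200 nM

In this assay, for the measured compounds named here, compound 2 holds the lowest of the two numbers recorded, and its only neighbour is compound 1, whose step is a 2.0-fold lower number from compound 1 to compound 2 (0.30 log units; within the scatter). Compound 3, `COc1ccc(/C=C/C(=O)c2ccc3c(c2)oc(=O)n3CN(C)C)cc1`, has not yet been measured in this assay. It differs from compound 2 in one place: (dimethylamino)methyl in place of hydrogen on an aromatic nitrogen. Going by the values given here, neither measured step touches this position or this kind of group; the single step known, between compound 1 and compound 2, concerns a methoxy on an aromatic carbon and was itself within the scatter, so it gives no direction for a change at the ring nitrogen. With nothing in the data pointing either way, compound 3 is expected to land close to compound 2, a step of a 1.0-fold lower number from compound 2 to compound 3 (0.01 log units; within the scatter) that would not exceed the scatter. The estimate for compound 3 in this assay is therefore 9000 nM, with a range from 3000 nM to 27000 nM.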

Compound 3, half-maximal inhibitory concentration: 17700 nM
Compound 3: the middle estimate sits 2.0-fold (0.29 log units) below what was measured; low and high end bracket the measured number.
By their numbers in this assay, from the lowest: compounds 2, 3 and 1 (each within the scatter of the next).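

In this assay the change on the aromatic nitrogen of the five-membered aromatic ring gives a 1.9-fold higher number from compound 2 to compound 3 (0.28 log units; within the scatter), so replacing hydrogen with (dimethylamino)methyl, a group of 4 heavy atoms with no ring, does not carry the number beyond the scatter. For the compounds shown here, the earlier step spoke only of a methoxy on an aromatic carbon, whereas this one is the first reading at the ring nitrogen, and it shows that the hydrogen there can give way to this group with compound 3 staying within the scatter of compound 2. No accompanying measurement bears on this result.

What the compounds shown leave open is whether a different group on the same nitrogen, such as a plain methyl, a longer chain ending in a morpholine, or a carboxylic acid, would give a step beyond the scatter. They also leave open whether (dimethylamino)methyl would give a similar step on the core of compound 1, which has hydrogen where compound 2 has methoxy.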